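Swapping One Aryl Ring on a Cytotoxicity-Silent Scaffold

The source may hold more compounds than are shown below. What is called first, only, known or untested is meant among the compounds shown, and "the series" means these compounds.

In an ADME assay on BJ cells (Homo sapiens) for cytotoxicity, read by CellTiter-Glo and resazurin assay, with a stated time of 72 h (a higher number here means that more compound is needed for the effect, a lower number that less compound is needed), compound 2 `COc1cc(OC)cc(-c2ccc(C(=O)N(Cc3cccc(OCCCCCC(=O)O)c3)C(C)C)cc2)c1` gives only a limit of the assay, > 26000 nM, so its result is a boundary rather than a number. Compound 1 `CC(=O)Nc1cccc(-c2ccc(C(=O)N(Cc3cccc(OCCCCCC(=O)O)c3)C(C)C)cc2)c1` likewise reaches only a limit, > 26000 nM. Both values sit at the limit of > 26000 nM in this assay, at which 2 of the 2 values shown sit, and the step that the two limits leave unreadable from compound 1 to compound 2 therefore cannot be read as a size. Compound 3 `CC(C)N(Cc1cccc(OCCCCCC(=O)O)c1)C(=O)c1ccc(-c2ccc(Cl)c(Cl)c2)cc1` has not yet been tested. It differs from compound 2 as follows: 3,4-dichlorophenyl in place of 3,5-dimethoxyphenyl on an aromatic carbon. Within the data shown here, the single measured step in this assay is unreadable, so nothing in the numbers shows how exchanging one aromatic ring of carbon only for another moves the read-out; the change leading to compound 3 is of just that kind. With both known values resting at the limit, the expectation for compound 3 is that the step of a number no higher from compound 2 to compound 3 (the limit leaves the size open) stays within the scatter. Compound 3 is thus estimated at 26000 nM, between 8000 nM and 80000 nM, with a fair chance that this assay once more reports only a limit.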

Compound 3, half-maximal effective concentration: > 26000 nM
Compound 3: a limit, no number (the forecaster's own chance of this, stated with the estimate: 70%); the middle value sits exactly at the limit.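

In this assay compound 3 gives > 26000 nM, which is a limit and not a number, so its steps from compound 1 and compound 2 cannot be read as sizes: the limit of > 26000 nM in this assay, at which 3 of the 3 values shown sit. The compounds shown leave open whether exchanging one of these aromatic rings for another changes the read-out at all, and at what concentration any of the three affects the cells.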